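Swapping the bromophenyl of compound 2 for a dichlorophenyl

The compounds below may be only part of what the source reports. "The series", "measured", "known", "first", "only" and "open" are said of these compounds alone.

Measured compounds:
compound 1 `Cc1ccc(-c2ccccc2S(=O)(=O)N2CCC(N3CCC(C)CC3)CC2)cc1` 366 nM
compound 2 `CC1CCN(C2CCN(S(=O)(=O)c3ccccc3Br)CC2)CC1` 3 nM
compound 3 `CC1CCN(C2CCN(S(=O)(=O)c3ccccc3-c3ccc(Cl)cc3)CC2)CC1` 202 nM

In a functional assay on DLD-1 cells (Homo sapiens) for antiproliferative activity, read by CellTiter-Glo, with a stated time of 72 h (a lower number here means a stronger inhibitor, a higher number a weaker inhibitor), compound 2 has the lowest number of the three, and it is the strongest inhibitor of this set, because both a 67-fold higher number from compound 2 to compound 3 (1.83 log units; beyond the scatter) and the reverse of a 120-fold lower number from compound 1 to compound 2 (2.09 log units; beyond the scatter) lie beyond the scatter. Compound 4 `CC1CCN(C2CCN(S(=O)(=O)c3ccc(Cl)cc3Cl)CC2)CC1` is not yet measured; it differs from compound 2 by 2,4-dichlorophenyl in place of 2-bromophenyl on a sulfonyl sulfur.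

Among the compounds with values here, two measured steps bear on this. Replacing bromo with 4-methylphenyl or with 4-chlorophenyl gave large jumps upward, a 120-fold lower number from compound 1 to compound 2 (2.09 log units; beyond the scatter) seen in reverse and a 67-fold higher number from compound 2 to compound 3 (1.83 log units; beyond the scatter); an aryl group in that place cost much, a halogen kept the low number. Compound 4 keeps a halogen there (chloro rather than bromo) and adds a second chloro, a change for which no direct comparison exists here. Compound 4 is therefore expected to stay close to compound 2, with at most a modest rise: a 2.7-fold higher number from compound 2 to compound 4 (0.43 log units; beyond the scatter). The estimate for compound 4 is 8 nM, within 2 nM to 40 nM.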

Compound 4, half-maximal inhibitory concentration: 1 nM
Compound 4: middle estimate off by 8.0-fold (0.90 log units), on the high side; measured number outside the range, below it.
By their numbers in this assay, from the lowest: compound 4; then compound 2; then compounds 3 and 1 (each within the scatter of the next).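

In this assay the aromatic ring on the sulfonyl sulfur accepts more than a single bromo: moving to 2,4-dichlorophenyl gave a 3.0-fold lower number from compound 2 to compound 4 (0.48 log units; beyond the scatter), a modest step that goes down, whereas the aryl groups of compound 1 and compound 3 sat at much higher numbers than compound 2. So a low number here is not tied to bromine, and a ring carrying two chloro groups does at least as well as one carrying a single bromo. Nothing measured here explains why this ring gives the lower number.

The step swaps bromo for chloro and adds a second chloro at once, so the compounds shown leave open which of the two changes accounts for the drop. They also leave open how this ring would respond to a nitrile or a methoxy group in place of a halogen.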